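This account rests on a few compounds, and the source may have more. Where it says the series, first, only, none or still open, it means among the compounds named here.

Measured so far in a functional assay on HT-29 cells (Homo sapiens) for antiproliferative activity, read by sulforhodamine B assay, with a stated time of 48 h; a lower number here means a stronger inhibitor of growth, a higher number a weaker inhibitor of growth: compound 1 `COc1ccccc1-c1cc(N2CCC(CNS(N)(=O)=O)CC2)ncn1`, compound 2 `COc1ccc(-c2cc(N3CCC(CCNS(N)(=O)=O)CC3)ncn2)cc1`, compound 3 `NS(=O)(=O)NCCC1CCN(c2cc(-c3ccc(Cl)cc3)ncn2)CC1`.

In this assay compound 1 gives only a limit, > 100000 nM. Compound 2 gives 72300 nM. Compound 3 gives 30500 nM, the lowest of the two numbers shown.

Compound 4 `COc1ccccc1-c1cc(N2CCC(CCNS(N)(=O)=O)CC2)ncn1` is not yet measured; it carries 2-methoxyphenyl in place of 4-chlorophenyl on an aromatic carbon. Going by the values given here, the only measured step at this part of the molecule is a 2.4-fold lower number from compound 2 to compound 3 (0.37 log units; beyond the scatter), which ran in the opposite sense, chloro replacing methoxy. Read backwards it points to a modest rise in the number. Compound 1 shares the 2-methoxyphenyl of compound 4 and sits at the limit (the limit of > 100000 nM in this assay, at which 1 of the 3 values shown sits). For compound 4 a step of a 3.0-fold higher number from compound 3 to compound 4 (0.47 log units; beyond the scatter) is therefore expected, toward a weaker inhibitor. The estimate for compound 4 is 90000 nM, with a range from 40000 nM to 200000 nM.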

Compound 4, concentration for 50% growth inhibition: 74300 nM
Compound 4: middle estimate off by 1.2-fold (0.08 log units), on the high side, within the range that was stated.
By their numbers in this assay, from the lowest: compound 3; then compounds 2 and 4 (each within the scatter of the next). At a limit, above all of these: compound 1.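

In this assay, the 2-methoxyphenyl and 4-methoxyphenyl groups are not told apart, with a 1.0-fold higher number from compound 2 to compound 4 (0.01 log units; within the scatter). The 4-chlorophenyl group remains apart from the 2-methoxyphenyl group, with a 2.4-fold higher number from compound 3 to compound 4 (0.39 log units; beyond the scatter), so a change of substituent separates these compounds, while moving the methoxy group does not. The chain change yields only a bound, an at least 1.3-fold lower number from compound 1 to compound 4 (0.12 log units; that floor lies within the scatter), with one end at a limit: the limit of > 100000 nM in this assay, at which 1 of the 4 values shown sits.

Still open, on these data alone, is whether an amine or a carboxylic acid in place of the sulfamoylamino group would change the number. As far as these compounds go, the effect of a longer chain also remains open.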